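From a 3-methylphenyl to a 4-bromophenyl group

The source may hold more compounds than are shown below. What is called first, only, known or untested is meant among the compounds shown, and "the series" means these compounds.

Measured in a functional assay on PC-3 cells (Homo sapiens) for inhibition, read by sulforhodamine B assay; a higher number here means a weaker inhibitor of growth, a lower number a stronger inhibitor of growth:
- compound 1 `COc1cccc(CN2CCC=C(CCC(=O)NO)C2=O)c1`: > 10000 nM (a limit)
- compound 2 `COc1ccc(CN2CCC=C(CCC(=O)NO)C2=O)cc1`: 7080 nM
- compound 3 `Cc1cccc(CN2CCC=C(CCC(=O)NO)C2=O)c1`: > 10000 nM (a limit)

The value of compound 3 is a limit and not a number: > 10000 nM. Compound 1 stands at the same limit, and the series shows (the limit of > 10000 nM in this assay, at which 2 of the 3 values shown sit). Only compound 2 gives a number, 7080 nM.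

Compound 4 `O=C(CCC1=CCCN(Cc2ccc(Br)cc2)C1=O)NO` keeps the core of compound 3 but carries 4-bromophenyl in place of 3-methylphenyl on a saturated chain carbon bound to an amide-type nitrogen in a ring. Going by the values given here, the one measured step, a step that the two limits leave unreadable from compound 1 to compound 3, offers no size to carry over. Among the compounds with values here, the expectation therefore rests on compound 2 at 7080 nM, the only readable value, and it remains weak evidence.

In this assay, a modest move toward stronger growth inhibition is expected, estimated as an at least 1.6-fold lower number from compound 3 to compound 4 (0.22 log units; that floor lies within the scatter). Compound 4 may still report only a limit. Compound 4 is estimated at 6000 nM, with an expected range of 2500 nM to 13000 nM.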

Compound 4, concentration for 50% growth inhibition: 3150 nM
Compound 4: the middle estimate sits 1.9-fold (0.28 log units) above what was measured; measured number inside the range.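

In this assay, compound 3 stands at a limit, > 10000 nM. Even so, 4-bromophenyl in place of 3-methylphenyl on a saturated chain carbon bound to an amide-type nitrogen in a ring gives a step with a readable floor, which the earlier compounds could not provide at this place: an at least 3.1-fold lower number from compound 3 to compound 4 (0.50 log units; beyond the scatter). Swapping the methoxy group for a bromo group also leaves the measured range of the series, with a 2.2-fold lower number from compound 2 to compound 4 (0.35 log units; beyond the scatter).

As far as these compounds go, only compound 2 and compound 4 give numbers, so the series offers little to compare: the limit of > 10000 nM in this assay, at which 2 of the 4 values shown sit. How a 4-chlorophenyl or a 4-aminophenyl group would read at this place remains open, as does the effect of a longer chain on the same nitrogen.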